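Swapping Propoxy for Cyclopentylamino: What Compound 3 Might Show

The source may report more compounds than this note shows. Statements on the series, on what has been measured and on what is new or still open speak of the compounds shown alone.

Of the compounds shown here, two have so far been measured in a functional assay for antagonist activity at transient receptor potential cation channel subfamily V member 1 (Rattus norvegicus); a lower number here means a stronger inhibitor, a higher number a weaker inhibitor. Compound 1 `Cc1cccnc1-c1ccc(C(=O)Nc2ccc(C(C)C)cc2)cc1` gives 43 nM in this assay . Compound 2 `CCCOc1cccnc1-c1ccc(C(=O)Nc2ccc(C(C)(C)C)cc2)cc1` gives 20 nM in this assay . Within the data shown here, compound 2 therefore stands at the lowest of the two numbers; its only neighbour, compound 1, sits at a higher number, and that gap lies beyond the usual scatter. Among the measured compounds shown here, because the two differ in more than one place, no single-change step between them can be read off.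

Compound 3 `CC(C)(C)c1ccc(NC(=O)c2ccc(-c3ncccc3NC3CCCC3)cc2)cc1` has not yet been measured in this assay . Relative to compound 2 the change is cyclopentylamino in place of propoxy on an aromatic carbon. Neither measured compound carries an amino group at that position, so no shown step speaks to this change, and the direction of any effect is open. The step is expected to be a 1.3-fold higher number from compound 2 to compound 3 (0.10 log units; within the scatter), modest and not clearly beyond the scatter in either direction. For compound 3 the expected value in this assay is 25 nM, with a plausible range from 6 nM to 100 nM.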

Compound 3, half-maximal inhibitory concentration: 44 nM
The estimate for compound 3 lay 1.8-fold (0.25 log units) below the measured number; measured number inside the range.
By their numbers in this assay, from the lowest: compound 2; then compounds 1 and 3 (each within the scatter of the next).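

In this assay, among these compounds, the first single-change step falls at the aromatic carbon two atoms from the ring nitrogen, and it shows that this position responds to the group it carries: a 2.2-fold higher number from compound 2 to compound 3 (0.34 log units; beyond the scatter). The step is modest, and compound 3 still gives 44 nM, so a group with a nitrogen link and a five-membered non-aromatic ring of carbon only is accepted here, even though it is larger than propoxy and brings in a hydrogen-bond donor that propoxy lacks. Nothing measured here ties the step to any one feature of the change, whether the nitrogen, the ring or the size of the group.

Which of these features carries the step stays open, and a cyclopentyloxy group or an open-chain propylamino group at this position would separate the ring from the nitrogen link. Compound 1 differs from compound 3 in more than one place, so its number adds nothing on this question, and whether a simple amino group or a longer alkoxy chain would fare better at this position is also unresolved.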